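The compounds below may be only part of what the source reports. "The series", "measured", "known", "first", "only" and "open" are said of these compounds alone.

Compound 1 `Cn1c([N+](=O)[O-])cnc1/C=C/c1ccccc1Br`: 72400 nM
Compound 2 `Cn1c([N+](=O)[O-])cnc1/C=C/c1ccc(Br)cc1`: 72400 nM
Compound 3 `Cn1c([N+](=O)[O-])cnc1/C=C/c1ccccc1Cl`: > 100000 nM

All three were tested in an ADME assay on HeLa cells (Homo sapiens) for cytotoxicity, read by resazurin assay, with a stated time of 2 days; on this read-out higher numbers stand for weaker inhibition and lower numbers for stronger inhibition. The value of compound 3 is a limit of this assay, not a number (the limit of > 100000 nM in this assay, at which 1 of the 3 values shown sits). Compound 1 and compound 2 are built from the same atoms joined differently; how their cores differ is not broken down here. In this assay compound 2 shows the same value as compound 1 at the digits given, which lies within the scatter. From compound 1 to compound 3 the change is chloro in place of bromo on an aromatic carbon, and it made an at least 1.3-fold higher number from compound 1 to compound 3 (0.14 log units; that floor lies within the scatter).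

Compound 4 `Cn1c([N+](=O)[O-])cnc1/C=C/c1ccc(Cl)cc1` has not yet been measured. It differs from compound 2 by chloro in place of bromo on an aromatic carbon. The place is not the same word for word: ortho to a large group in the first pair, para to a large group in the second, so this is the same kind of change, not the same one. Resting on an at least 1.3-fold higher number from compound 1 to compound 3 (0.14 log units; that floor lies within the scatter), compound 4 is expected to move by a 1.5-fold higher number from compound 2 to compound 4 (0.18 log units; within the scatter). Compound 4 is therefore estimated at 110000 nM, quite possibly reported only as a limit.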

Compound 4, half-maximal inhibitory concentration: 91200 nM
Beside the measured number, compound 4's estimate is 1.2-fold (0.08 log units) above it; low and high end bracket the measured number.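

In this assay, putting chloro in place of bromo on the aromatic carbon para to a large group gave a 1.3-fold higher number from compound 2 to compound 4 (0.10 log units; within the scatter), so on this core the swap moves the read-out by no more than repeated measurements normally would. Compound 3 gives > 100000 nM, which is a limit of the assay and not a number. The swap can therefore be set beside its counterpart on the core of compound 1 only loosely, and these pairs do not show that the change carries from one core to the other at the same size: the same change on two cores in this assay, an at least 1.3-fold higher number (0.14 log units; that floor lies within the scatter) from compound 1 to compound 3 and a 1.3-fold higher number (0.10 log units; within the scatter) from compound 2 to compound 4; the limit leaves it open whether they differ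

The compounds shown carry only bromo or chloro on the six-membered aromatic ring, so they leave open how a different group there, such as an amine, a carboxylic acid or a longer chain, would read in this assay. They also leave open whether the swap would behave the same way if the nitro group were replaced, for instance by a nitrile.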